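Bromine for Chlorine at the Anilino Position

The compounds below may be only part of what the source reports. "The series", "measured", "known", "first", "only" and "open" are said of these compounds alone.

In a functional assay on U2OS cells (Homo sapiens) for cytotoxicity, read by MTT assay, with a stated time of 48 h (on this read-out lower numbers stand for stronger inhibition and higher numbers for weaker inhibition), compound 1 `COc1ccccc1Nc1nc(-c2cccc(F)c2)nc2ccc(F)cc12` gives > 50000 nM, which is a limit of the assay rather than a number. Compound 2 `Fc1cccc(-c2nc(Nc3ccc(Cl)cc3)c3cc(F)ccc3n2)c1` gives 38400 nM in this assay. Compound 3 `Fc1cccc(-c2nc(Nc3ccccc3Cl)c3cc(F)ccc3n2)c1` gives > 50000 nM in this assay, again a limit. Compound 1 thus stands only at a limit, and two of the three values sit at the limit of > 50000 nM in this assay, at which 2 of the 3 values shown sit, so no ordering among the three can be claimed. The step of an at least 1.3-fold lower number from compound 1 to compound 2 (0.11 log units; that floor lies within the scatter) and the step of an at least 1.3-fold higher number from compound 2 to compound 3 (0.11 log units; that floor lies within the scatter) are floors inside the scatter, and the step that the two limits leave unreadable from compound 1 to compound 3 cannot be read.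

Compound 4 `Fc1cccc(-c2nc(Nc3ccc(Br)cc3)c3cc(F)ccc3n2)c1` has not yet been measured. It differs from compound 1 as follows: 4-bromophenyl in place of 2-methoxyphenyl on a nitrogen on an aromatic ring. The measured step that bears on this change is an at least 1.3-fold lower number from compound 1 to compound 2 (0.11 log units; that floor lies within the scatter), in which 4-chlorophenyl replaced the same 2-methoxyphenyl on the nitrogen on an aromatic ring. The step expected in this assay is therefore small, an at least 1.2-fold lower number from compound 1 to compound 4 (0.09 log units; that floor lies within the scatter), or none beyond the scatter. Compound 4 is estimated at 40000 nM, with a range of 20000 nM to 60000 nM, and a fair chance that only a limit is returned.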

Compound 4, half-maximal inhibitory concentration: > 50000 nM
Compound 4: a limit, no number (the forecaster's own chance of this, stated with the estimate: 50%); middle value at least 1.2-fold (0.09 log units) away from the limit.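

On this position, the exchange of chloro for bromo on an aromatic carbon yields only an at least 1.3-fold higher number from compound 2 to compound 4 (0.11 log units; that floor lies within the scatter), so this assay shows neither that this change matters nor that it does not. The steps from compound 1 and from compound 3 to compound 4 cannot be read. Compound 2 is now the only one of the four with a number, and a 4-halophenyl on this nitrogen no longer ensures a value under the limit, as compound 4 shows: the limit of > 50000 nM in this assay, at which 3 of the 4 values shown sit.

From the compounds shown here alone, whether the small gap between compound 2 and compound 4 is real stays open, since a limit cannot settle it. Also open, going by these compounds, is whether an amine or a carboxylic acid in place of the bromo would return a number at all.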